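The source may hold more compounds than are shown below. What is called first, only, known or untested is meant among the compounds shown, and "the series" means these compounds.

Three compounds share one core, differing only in the chain on the aromatic nitrogen of the five-membered ring. Compound 1 `CCn1ncnc1-c1ccccc1NCC1=NCCN1` carries an ethyl group and in an in vitro functional assay on cells (Fibroblast) for agonist activity at Alpha-1D adrenergic receptor (Homo sapiens) (a higher number here means that more compound is needed for the effect, a lower number that less compound is needed), compound 1 gives 126 nM. Compound 2 `CCCn1ncnc1-c1ccccc1NCC1=NCCN1` carries a propyl group; in this assay compound 2 gives 251 nM. Compound 3 `CCCCn1ncnc1-c1ccccc1NCC1=NCCN1` carries a butyl group, and in this assay compound 3 gives 398 nM, the largest of the three numbers, although its gap to compound 2 is within the scatter. Each lengthening of the chain moved the number the same way: a 2.0-fold higher number from compound 1 to compound 2 (0.30 log units; within the scatter), a 1.6-fold higher number from compound 2 to compound 3 (0.20 log units; within the scatter), and taken together a 3.2-fold higher number from compound 1 to compound 3 (0.50 log units; beyond the scatter).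

Compound 4 `CC(C)n1ncnc1-c1ccccc1NCC1=NCCN1` is the next step: isopropyl in place of butyl on an aromatic nitrogen. The chain thus loses one carbon and becomes branched, returning to the three-carbon count of compound 2. Going by these compounds, the three measured steps all concern chain length, and they suggest that fewer chain carbons go with a somewhat lower number; none of them tests branching, so that part of the change is unknown. The expected step is therefore modest and downward, a 1.6-fold lower number from compound 3 to compound 4 (0.20 log units; within the scatter), close to what compound 2 shows. For compound 4 the estimate in this assay is 250 nM, with a range from 120 nM to 520 nM.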

Compound 4, half-maximal effective concentration: 3160 nM
Beside the measured number, compound 4's estimate is 13-fold (1.10 log units) below it; the measured number lies above the stated range.
By their numbers in this assay, from the lowest: compounds 1, 2 and 3 (each within the scatter of the next, the first and the last beyond it); then compound 4.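

In this assay, the number of carbons in the chain does not alone set the result: isopropyl in place of propyl keeps that count but gives a 13-fold higher number from compound 2 to compound 4 (1.10 log units; beyond the scatter). The branched chain also stands apart from the longer straight chain, with a 7.9-fold higher number from compound 3 to compound 4 (0.90 log units; beyond the scatter), so on this aromatic nitrogen branching counts for more than anything the chain-length steps showed. Methyl in place of hydrogen on the saturated chain carbon bound to the aromatic nitrogen gives a 25-fold higher number from compound 1 to compound 4 (1.40 log units; beyond the scatter), and the same kind of change three bonds along the chain gives a far smaller step, so where the methyl sits along the chain matters greatly: the same change on two cores in this assay, a 1.6-fold higher number (0.20 log units; within the scatter) from compound 2 to compound 3 and a 25-fold higher number (1.40 log units; beyond the scatter) from compound 1 to compound 4, 16-fold (1.20 log units) apart, beyond the scatter of two such steps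

Going by these compounds alone, with isopropyl as the only branched group here, it remains open whether any branch on the chain carbon bound to the aromatic nitrogen raises the number this much, which a cyclopropyl or tert-butyl group there would test, or whether a branch further out, as in an isobutyl chain, does the same. Going by these compounds, it is also open whether the chain-length trend continues downward to a methyl group on this nitrogen.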